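Adding a second chloro to the pendant ring of compound 3

The compounds below may be only part of what the source reports. "The series", "measured", "known", "first", "only" and "open" are said of these compounds alone.

The three measured compounds share one core and differ only in the aryl ring on the saturated ring carbon. In a functional assay on Ehrlich cells (Mus musculus) for cytotoxicity, read by trypan blue exclusion, with a stated time of 2 h, tested at 50 ug/mL (a higher number here means a stronger effect of the compound at the concentration tested, a lower number a weaker effect), compound 1 `Cc1ccc(C2C(C#N)=C(N)N(c3ccc(S(N)(=O)=O)cc3)C3=C2CCCC3)cc1` gives 80%, and compound 2 `COc1ccc(C2C(C#N)=C(N)N(c3ccc(S(N)(=O)=O)cc3)C3=C2CCCC3)cc1` gives 100%. Compound 3 `N#CC1=C(N)N(c2ccc(S(N)(=O)=O)cc2)C2=C(CCCC2)C1c1ccccc1Cl` gives 5%, the lowest of the three numbers; its nearest neighbour is compound 1, the furthest compound 2, as the steps of a number 75 percentage points lower from compound 1 to compound 3 (beyond the scatter) and a number 95 percentage points lower from compound 2 to compound 3 (beyond the scatter) show. The step between compounds 1 and 2, a number 20 percentage points higher from compound 1 to compound 2 (beyond the scatter), is modest by comparison.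

Compound 4 `N#CC1=C(N)N(c2ccc(S(N)(=O)=O)cc2)C2=C(CCCC2)C1c1ccc(Cl)cc1Cl` is not yet measured. It differs from compound 3 by chloro in place of hydrogen on an aromatic carbon. Going by the values given here, no measured step adds a chloro to an aryl ring; the two large steps above merely show that what is carried on this ring moves the number strongly in this assay. Both 4-methylphenyl and 4-methoxyphenyl compounds sit high, while the 2-chlorophenyl compound sits low, so the direction for a 2,4-dichlorophenyl is uncertain, with room for a rise.

Compound 4 is therefore expected to give about 30% in this assay, within 5% to 70%, an estimated step of a number 25 percentage points higher from compound 3 to compound 4 (beyond the scatter).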

Compound 4, a percentage reported as activity, at one concentration (the size of the read-out at that concentration, not a potency): 50%
Compound 4: the middle estimate sits 20 percentage points below what was measured; measured number inside the range.
By their numbers in this assay, from the lowest: compound 3; then compound 4; then compound 1; then compound 2.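

A chloro in place of hydrogen, para to a large group and meta to a chloro group, is the first addition to this aryl ring among the compounds shown, and in this assay it gives a large rise (a number 45 percentage points higher from compound 3 to compound 4 (beyond the scatter)). The low number of compound 3 is therefore not fixed by the chloro it already carries, since the 2,4-dichlorophenyl ring, which keeps that chloro, reads clearly higher. The rise still leaves the ring short of the two other aryl rings, as the steps to it show (a number 30 percentage points lower from compound 1 to compound 4 (beyond the scatter); a number 50 percentage points lower from compound 2 to compound 4 (beyond the scatter)), and nothing in the data shown explains why this added chloro moves the number.

From the compounds shown here alone, it remains open whether the new chloro would raise the number without the chloro already on the ring, so its contribution cannot be separated from that of the 2,4-dichlorophenyl pattern as a whole. Going by these compounds, it is equally open whether the rise is particular to chloro at this place, or whether a methyl, a methoxy, an amine or a carboxylic acid there would move the number the same way.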